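Shortening the ethoxy group to methoxy

The compounds below may be only part of what the source reports. "The series", "measured", "known", "first", "only" and "open" are said of these compounds alone.

Measured in a functional assay on A549 cells (Homo sapiens) for cytotoxicity, read by MTT assay; on this read-out higher numbers stand for weaker inhibition and lower numbers for stronger inhibition:
- compound 1 `C=C1C(=O)[C@]23C[C@@]1(O)CC[C@H]2[C@@]12C=CC(=O)[C@](C)(C(=O)O1)[C@H]2[C@@H]3C(=O)OCc1ccccc1`: 23900 nM
- compound 2 `C=C1C(=O)[C@]23C[C@@]1(OCC)CC[C@H]2[C@@]12C=CC(=O)[C@](C)(C(=O)O1)[C@H]2[C@@H]3C(=O)OCc1ccccc1`: 24200 nM

Within the data shown here, compound 2, at 24200 nM, stands within the scatter of compound 1, the only other measured compound. The next compound is compound 3 `C=C1C(=O)[C@]23C[C@@]1(OC)CC[C@H]2[C@@]12C=CC(=O)[C@](C)(C(=O)O1)[C@H]2[C@@H]3C(=O)OCc1ccccc1`. It differs from compound 2 by hydrogen in place of methyl on a saturated chain carbon bound to an oxygen on a saturated carbon, or ethoxy to methoxy. Among the measured compounds shown here, one measured step bears on this change at the same oxygen: a 1.0-fold higher number from compound 1 to compound 2 (0.01 log units; within the scatter), for ethyl in place of hydrogen on an oxygen on a saturated carbon. That step lies within the scatter, so no change beyond the scatter is expected here. The estimated step is a 1.0-fold lower number from compound 2 to compound 3 (0.00 log units; within the scatter). For compound 3 the expected value is 24000 nM, with an estimated range of 14000 nM to 40000 nM.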

Compound 3, half-maximal inhibitory concentration: 28200 nM
For compound 3 the middle estimate is 1.2-fold (0.07 log units) below the measured one; the range from low to high includes it.
By their numbers in this assay, from the lowest: compounds 1, 2 and 3 (each within the scatter of the next).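

In this assay, ethoxy to methoxy gives a 1.2-fold higher number from compound 2 to compound 3 (0.07 log units; within the scatter) and methyl in place of hydrogen on the oxygen gives a 1.2-fold higher number from compound 1 to compound 3 (0.07 log units; within the scatter), both within the scatter. Hydrogen, methyl and ethyl on this oxygen now all read alike, so the flat result no longer rests on the single comparison of hydrogen with ethyl. Nothing available here accounts for this flat read-out at the oxygen.

On these data alone, whether the position stays flat beyond these three remains open, as a longer chain or a chain carrying an amine on this oxygen could read differently. All three compounds also share the benzyl ester, so they give no information on how a carboxylic acid in its place would read.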